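The source may report more compounds than this note shows. Statements on the series, on what has been measured and on what is new or still open speak of the compounds shown alone.

Measured so far in this series:
compound 1 `COc1ccccc1-c1ccc(S(=O)(=O)N2CCC(N3CCC(C)CC3)CC2)cc1` — 26 nM
compound 2 `CC1CCN(C2CCN(S(=O)(=O)c3ccc(-c4ccccc4F)cc3)CC2)CC1` — 5 nM
compound 3 `CCCOc1ccc(S(=O)(=O)N2CCC(N3CCC(C)CC3)CC2)cc1` — 452 nM

In a functional assay on DLD-1 cells (Homo sapiens) for antiproliferative activity, read by CellTiter-Glo, with a stated time of 72 h (a lower number here means a stronger inhibitor, a higher number a weaker inhibitor), compound 3 carries the highest number of the three. The two gaps are shown by a 17-fold higher number from compound 1 to compound 3 (1.24 log units; beyond the scatter) and by a 90-fold higher number from compound 2 to compound 3 (1.96 log units; beyond the scatter); both are beyond the scatter, so compound 3 is the weakest inhibitor among the measured compounds.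

Compound 4 `CC1CCN(C2CCN(S(=O)(=O)c3ccc(-c4ccc(Cl)cc4)cc3)CC2)CC1` is not yet measured. It differs from compound 3 in one place: 4-chlorophenyl in place of propoxy on an aromatic carbon. Going by the values given here, two measured steps bear directly on this change, as both replaced an aryl group at the same position with propoxy: a 17-fold higher number from compound 1 to compound 3 (1.24 log units; beyond the scatter) and a 90-fold higher number from compound 2 to compound 3 (1.96 log units; beyond the scatter), each a large rise in the number. The step to compound 4 runs the other way, putting an aryl ring back in place of propoxy. The aryl rings of compound 1 and compound 2 carried their substituent in a different place than the 4-chlorophenyl of compound 4, and a 5.2-fold lower number from compound 1 to compound 2 (0.72 log units; beyond the scatter) shows that the substituent on that ring itself shifts the number only modestly. A large fall in the number is therefore expected, on the order of a 30-fold lower number from compound 3 to compound 4 (1.48 log units; beyond the scatter). Compound 4 is estimated at 15 nM, with a range of 4 nM to 60 nM.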

Compound 4, half-maximal inhibitory concentration: 105 nM
The estimate for compound 4 lay 7.0-fold (0.85 log units) below the measured number; measured number outside the range, above it.
By their numbers in this assay, from the lowest: compound 2; then compound 1; then compound 4; then compound 3.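

In this assay an aryl ring in place of propoxy does not by itself restore the low numbers of compound 1 and compound 2: the change gives only a 4.3-fold lower number from compound 3 to compound 4 (0.63 log units; beyond the scatter) as a modest step, whereas the 2-methoxyphenyl and 2-fluorophenyl rings stood much further from propoxy. Which aryl ring sits at this position therefore matters as well as whether one is there, since 4-chlorophenyl in place of 2-methoxyphenyl gives a 4.0-fold higher number from compound 1 to compound 4 (0.61 log units; beyond the scatter) and in place of 2-fluorophenyl gives a 21-fold higher number from compound 2 to compound 4 (1.32 log units; beyond the scatter) as a large step, wider than the gap between the two earlier aryl compounds. Nothing available accounts for these differences between the rings.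

4-Chlorophenyl differs from the two earlier rings both in its substituent and in where that substituent sits, so the compounds shown cannot separate the contribution of chlorine from that of its place on the ring. From the compounds shown here alone, it also remains open how an unsubstituted phenyl ring, a phenyl ring bearing a nitrile or an amine, or an alkoxy chain longer than propoxy would read at this position.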